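This account rests on a few compounds, and the source may have more. Where it says the series, first, only, none or still open, it means among the compounds named here.

Working notes on the series.

Compound 1 `COc1ccc(C(=O)/C=C/c2cc(-c3cc(OC)c(OC)c(OC)c3)n3nc(-c4ccccc4)cc3n2)cc1` gives 13200 nM in a functional assay on MDA-MB-231 cells (Homo sapiens) for antiproliferative activity, read by MTT assay, with a stated time of 24 h; on this read-out higher numbers stand for weaker inhibition and lower numbers for stronger inhibition. Of the three numbers shown it is the smallest, but neither of the other two is separated from it beyond the scatter: compound 3 `COc1ccc(C(=O)/C=C/c2cc(-c3ccc(OC)c(OC)c3)n3nc(-c4ccccc4)cc3n2)cc1` gives 13900 nM, and compound 2 `COc1cc(-c2cc(C(=O)/C=C/c3ccccc3)nc3cc(-c4ccccc4)nn23)cc(OC)c1OC` gives 19200 nM. Among the measured compounds shown here, the two measured steps are a 1.1-fold higher number from compound 1 to compound 3 (0.02 log units; within the scatter) and a 1.5-fold higher number from compound 1 to compound 2 (0.16 log units; within the scatter), so nothing so far moves the read-out beyond its scatter.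

Compound 4 `COc1ccc(C(=O)/C=C/c2cc(-c3cc(OC)c(OC)c(OC)c3)n3nc(-c4ccccc4)cc3n2)cc1OC` differs from compound 1 by methoxy in place of hydrogen on an aromatic carbon. The step that bears on it is a 1.1-fold higher number from compound 1 to compound 3 (0.02 log units; within the scatter), which removed a methoxy from an aromatic carbon of the other aryl group and changed nothing beyond the scatter; adding a methoxy here is expected to behave the same way, with no step beyond the scatter in this assay in either direction. The step from compound 1 to compound 4 is therefore estimated as a 1.1-fold lower number from compound 1 to compound 4 (0.04 log units; within the scatter), and compound 4 is expected to give 12000 nM in this assay, within a range of 5000 nM to 28000 nM.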

Compound 4, half-maximal inhibitory concentration: 18300 nM
Compound 4: middle estimate off by 1.5-fold (0.18 log units), on the low side; the range from low to high includes it.
By their numbers in this assay, from the lowest: compounds 1, 3, 4 and 2 (each within the scatter of the next).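

Going from 4-methoxyphenyl to 3,4-dimethoxyphenyl on the carbonyl side gives a 1.4-fold higher number from compound 1 to compound 4 (0.14 log units; within the scatter) in this assay, so adding a methoxy to this aryl group, ortho to the existing methoxy, does not move the read-out beyond its scatter. Together with a 1.5-fold higher number from compound 1 to compound 2 (0.16 log units; within the scatter), where compound 2 lacks the methoxy of the 4-methoxyphenyl group, this means that among these compounds neither removing a methoxy from this aryl group nor adding one gives a step beyond the scatter. Nothing available bears on the reason for this step.

The compounds shown leave open whether a group other than methoxy at this place, such as an amine or a carboxylic acid, would give a step beyond the scatter. They also leave open whether any change to the shared core would do so.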